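Swapping the aryl on the chain carbon: compound 2 to compound 4

A few compounds are considered here, and "the series" means these few. Any claim that something is new, unique, unknown or untested is made for them only; others in the source may bear on it.

The series shares one core, seen in compound 2 `COc1nc2ccc(Br)cc2cc1[C@@H](c1cc(C)c(C)s1)[C@@](O)(CCN(C)C)c1cccc(F)c1`, compound 1 `CCSc1ccc([C@H](c2cc3cc(Br)ccc3nc2OC)[C@@](O)(CCN(C)C)c2cccc(F)c2)cn1` and compound 3 `COc1nc2ccc(Br)cc2cc1[C@@H](c1ccnc(OC)c1OC)[C@@](O)(CCN(C)C)c1cccc(C)c1`, and varies the aryl group on a saturated chain carbon bound to an aromatic carbon and a saturated chain carbon. In an ADME assay on microsomes from liver (Homo sapiens) for metabolic stability (on this read-out lower numbers stand for a shorter-lived compound and higher numbers for a longer-lived compound), compound 2 gives 1 h; compound 1 gives 1.07 h and compound 3 gives 0.867 h. Compound 2 thus stands second highest of the three, but its gaps to both neighbours fall within the scatter, so no order among them can be read. Compound 4 `COc1nc2ccc(Br)cc2cc1[C@@H](c1ccc(N(C)C)nc1)[C@@](O)(CCN(C)C)c1cccc(F)c1` carries one change from compound 2: 6-(dimethylamino)pyridin-3-yl in place of 4,5-dimethylthiophen-2-yl on a saturated chain carbon bound to an aromatic carbon and a saturated chain carbon. Going by the values given here, the one step that bears on this place is a 1.1-fold lower number from compound 1 to compound 2 (0.03 log units; within the scatter), where the exchange of one aryl for another at the same carbon left the half-life essentially unchanged. On that basis compound 4 is expected to give about 1 h, within 0.5 h to 2 h, a step of no change at the digits printed from compound 2 to compound 4 (within the scatter) that is expected to stay within the scatter.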

Compound 4, half-life: 0.3 h
Estimate against measurement, compound 4: 3.3-fold (0.52 log units) above; the whole stated range lies above it.
By their numbers in this assay, from the lowest: compound 4; then compounds 3, 2 and 1 (each within the scatter of the next).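

In this assay, this position proves sensitive to the aryl group: the change from 4,5-dimethylthiophen-2-yl to 6-(dimethylamino)pyridin-3-yl gives a 3.3-fold lower number from compound 2 to compound 4 (0.52 log units; beyond the scatter), whereas the earlier aryl exchange, a 1.1-fold lower number from compound 1 to compound 2 (0.03 log units; within the scatter), stayed within the scatter. The pyridin-3-yl ring alone does not set the number, since replacing ethylsulfanyl with dimethylamino on an aromatic carbon of that ring gives a 3.6-fold lower number from compound 1 to compound 4 (0.55 log units; beyond the scatter). Nothing available accounts for this fall in half-life.

The compounds shown leave open whether the lower number belongs to dimethylamino specifically or would also appear with a smaller amine, such as methylamino, or with a methoxy group on the same ring. They also do not show whether the change would have the same effect with other groups elsewhere on the shared core.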